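Trading an aromatic acid for a chain acid

The source may hold more compounds than are shown below. What is called first, only, known or untested is meant among the compounds shown, and "the series" means these compounds.

Three measured compounds share one core and differ only in the group on an amine nitrogen in a ring. Compound 1 `O=C(c1ccccn1)N1CCC(NS(=O)(=O)c2cc(S(=O)(=O)c3ccccc3)ccc2C(F)(F)F)CC1` carries a (pyridin-2-yl)carbonyl there, and in an assay on isolated protein for displacement of a labelled ligand from secreted frizzled-related protein 1 (Homo sapiens), read by fluorescence polarization, with a stated time of 30 min (a lower number here means a stronger inhibitor, a higher number a weaker inhibitor), compound 1 gives 60 nM. Compound 2 `O=C(O)c1cccc(S(=O)(=O)N2CCC(NS(=O)(=O)c3cc(S(=O)(=O)c4ccccc4)ccc3C(F)(F)F)CC2)c1` carries a (3-carboxyphenyl)sulfonyl and gives 20 nM. Compound 3 `O=C(O)c1ccc(S(=O)(=O)N2CCC(NS(=O)(=O)c3cc(S(=O)(=O)c4ccccc4)ccc3C(F)(F)F)CC2)cc1` carries a (4-carboxyphenyl)sulfonyl and gives 20 nM. Compound 3 thus stands level with compound 2 at the lowest numbers of the three, since no change at the digits printed from compound 2 to compound 3 (within the scatter). Both acids sit below compound 1: a 3.0-fold lower number from compound 1 to compound 2 (0.48 log units; beyond the scatter) and a 3.0-fold lower number from compound 1 to compound 3 (0.48 log units; beyond the scatter).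

Compound 4 `O=C(O)CCCC(=O)N1CCC(NS(=O)(=O)c2cc(S(=O)(=O)c3ccccc3)ccc2C(F)(F)F)CC1` is not yet measured. Its difference from compound 3 is (3-carboxypropyl)carbonyl in place of (4-carboxyphenyl)sulfonyl on an amine nitrogen in a ring. The new group keeps a carboxylic acid, as in compounds 2 and 3, but joins the nitrogen through a carbonyl, as in compound 1, and has no ring at all. For the measured compounds named here, no measured step makes this exact exchange; the two that bear on it, from compound 1 to compound 2 and to compound 3, each show only a modest gain when a carboxyphenylsulfonyl replaces the pyridinylcarbonyl. A modest move back toward the level of compound 1 is therefore expected, a 2.3-fold higher number from compound 3 to compound 4 (0.35 log units; beyond the scatter). Compound 4 is expected to give 45 nM, in a range from 15 nM to 140 nM.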

Compound 4, half-maximal inhibitory concentration: 500 nM
The estimate for compound 4 lay 11-fold (1.05 log units) below the measured number, and the stated range ends below it.
By their numbers in this assay, from the lowest: compounds 2 and 3 (each within the scatter of the next); then compound 1; then compound 4.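

Keeping a carboxylic acid on an amine nitrogen in a ring does not by itself preserve the low numbers of the two aromatic acids in this assay: replacing the sulfonyl-linked carboxyphenyl groups with (3-carboxypropyl)carbonyl gives a large change in both direct comparisons (a 25-fold higher number from compound 3 to compound 4 (1.40 log units; beyond the scatter); a 25-fold higher number from compound 2 to compound 4 (1.40 log units; beyond the scatter)). Compound 4 also stands apart from compound 1, which has no carboxylic acid but shares the carbonyl link, with 3-carboxypropyl in place of pyridin-2-yl giving a clear move the other way (an 8.3-fold higher number from compound 1 to compound 4 (0.92 log units; beyond the scatter)), so the presence of a carboxylic acid does not track with a lower number across these four compounds. Nothing available here accounts for this drop.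

The change from compound 3 to compound 4 alters both the link to the nitrogen and the group carrying the acid, so these compounds cannot divide the effect between the sulfonyl, the carbonyl and the aromatic ring. A 4-carboxyphenyl joined through a carbonyl, or a 3-carboxypropyl joined through a sulfonyl, would separate those parts, while a longer chain ending in a carboxylic acid would probe the chain itself.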